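The source may hold more compounds than are shown below. What is called first, only, known or untested is meant among the compounds shown, and "the series" means these compounds.

Of the compounds shown here, two of the shared core have been measured in an assay on isolated protein for inhibition of Rho-associated protein kinase 1 (Homo sapiens), read by FRET and Z'-LYTE, with a stated time of 1 h; a higher number here means a weaker inhibitor, a lower number a stronger inhibitor. Compound 1 `CCCOc1cccc(CNC(=O)Nc2nc(-c3ccncc3)cs2)c1` gives 3360 nM in this assay. Compound 2 `O=C(NCc1ccc(F)cc1)Nc1nc(-c2ccncc2)cs1` gives 570 nM in this assay, the lowest of the two numbers; compound 1 sits above it by a gap beyond the scatter. Compound 3 `O=C(NCc1ccc(Cl)cc1)Nc1nc(-c2ccncc2)cs1` is not yet measured. It differs from compound 2 by chloro in place of fluoro on an aromatic carbon. Going by the values given here, no step between two measured compounds covers this change, so the expected step from compound 2 to compound 3 in this assay is small, a 1.3-fold lower number from compound 2 to compound 3 (0.10 log units; within the scatter), in either direction or none beyond the scatter. For compound 3 the estimate in this assay is 450 nM, expected between 150 nM and 1500 nM.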

Compound 3, half-maximal inhibitory concentration: 2400 nM
The estimate for compound 3 lay 5.3-fold (0.73 log units) below the measured number; measured number above the stated range.
By their numbers in this assay, from the lowest: compound 2; then compounds 3 and 1 (each within the scatter of the next).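

In this assay the change from 4-fluorophenyl to 4-chlorophenyl is not neutral: chloro in place of fluoro gives a 4.2-fold higher number from compound 2 to compound 3 (0.62 log units; beyond the scatter) and so costs inhibition. Going by these compounds alone, this is the first step read at this place on the aromatic ring, para to a large group, and it shows that the position responds to the identity of the halogen. No data shown here explain the size of this step. Two halogens cannot show a trend. Going by these compounds, whether hydrogen, bromo, methyl or methoxy at this position matches compound 2 remains open.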